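From 2,6-dichlorobenzyl to benzoylmethyl on the sulfur

The source may report more compounds than this note shows. Statements on the series, on what has been measured and on what is new or still open speak of the compounds shown alone.

Among the compounds with values here, in an ADME assay on GES1 cells (Homo sapiens) for inhibition, read by MTT assay, with a stated time of 72 h (a lower number here means a stronger inhibitor, a higher number a weaker inhibitor), compound 1 `Cc1cc(Nc2cc(-c3ccccc3)[nH]n2)n2nc(SCc3c(Cl)cccc3Cl)nc2n1` gives 39600 nM, the only exact number available so far. Compound 2 `CCCCCc1c(C)nc2nc(SCc3ccc(Cl)cc3)nn2c1Nc1cc(-c2ccccc2)[nH]n1` returns only a limit, > 50000 nM.

Compound 3 `Cc1cc(Nc2cc(-c3ccccc3)[nH]n2)n2nc(SCC(=O)c3ccccc3)nc2n1` keeps the core of compound 1 and alters one group on a saturated chain carbon bound to a sulfur, with benzoyl in place of 2,6-dichlorophenyl (benzoyl in place of 2,6-dichlorophenyl on a saturated chain carbon bound to a sulfur). Cut one bond further out, the same difference reads 2,6-dichlorobenzyl to benzoylmethyl.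

Within the data shown here, no measured pair shows what this change does in this assay, so no shift beyond the scatter is expected. The expected step of a 1.1-fold higher number from compound 1 to compound 3 (0.06 log units; within the scatter) is therefore small, and its direction is left open. A reading for compound 3 could come back only as a limit, and that outcome is expected to be a real possibility. For compound 3 the estimate is 45000 nM, with an expected range of 20000 nM to 90000 nM.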

Compound 3, half-maximal inhibitory concentration: 33300 nM
Estimate against measurement, compound 3: 1.4-fold (0.13 log units) above, and the stated range covers the measured number.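

In this assay, within the data shown here, the first pair that differs in one place gives a 1.2-fold lower number from compound 1 to compound 3 (0.08 log units; within the scatter) for benzoyl in place of 2,6-dichlorophenyl on a saturated chain carbon bound to a sulfur. Compound 1 and compound 3 therefore read alike, so at this position the exchange of a chlorine-bearing aromatic ring for a carbonyl-bearing one, which also brings in a hydrogen-bond acceptor, produces no shift beyond the scatter. Compound 2 gives only a limit, so it adds no number to this comparison: the limit of > 50000 nM in this assay, at which 1 of the 3 values shown sits.

The pair cannot separate the loss of the two chlorines from the entry of the carbonyl, and a plain benzyl on the sulfur would tell these two parts of the exchange apart. From the compounds shown here alone, whether this position can move the reading at all in this assay remains open, and an amine or a carboxylic acid at the end of the chain on the sulfur would test that with a group of a different kind.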